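The source may report more compounds than this note shows. Statements on the series, on what has been measured and on what is new or still open speak of the compounds shown alone.

Measured so far:
compound 1 `C[C@@H]1CCN(c2cc(-c3ccccc3)nc3ncnn23)C[C@@H]1N(C)c1ncnc2[nH]ccc12` — > 100000 nM
compound 2 `Cc1cc(N2CC[C@@H](C)[C@@H](N(C)c3ncnc4[nH]ccc34)C2)n2nc(SCc3nc4ccccc4[nH]3)nc2n1` — > 100000 nM
compound 3 `CCCCCc1c(C)nc2nc(SCc3ccc(Cl)cc3)nn2c1N1CC[C@@H](C)[C@@H](N(C)c2ncnc3[nH]ccc23)C1` — 32300 nM

All three compounds share the same core and are tested in a functional assay on BGC-823 cells (Homo sapiens) for inhibition, read by MTT assay, with a stated time of 72 h; a higher number here means a weaker inhibitor, a lower number a stronger inhibitor. Compound 2 gives only a limit of the assay there, > 100000 nM, so no number for it is known. Compound 1 also sits at a limit, > 100000 nM. Going by the values given here, compound 3 is the only one with a number, 32300 nM, and that number is weak. The picture is summed up by the limit of > 100000 nM in this assay, at which 2 of the 3 values shown sit: most of what has been measured falls outside the reach of this assay.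

Compound 4 `Cc1cc(N2CC[C@@H](C)[C@@H](N(C)c3ncnc4[nH]ccc34)C2)n2nc(SCc3ccc(F)cc3)nc2n1` has not yet been measured. It differs from compound 2 in one place: 4-fluorophenyl in place of 1H-benzimidazol-2-yl on a saturated chain carbon bound to a sulfur. Compound 3, which carries a related chlorine-bearing benzyl group on the same sulfur, does reach a number, so a small gain on compound 2 is expected; the step from compound 2 to compound 4 is estimated as an at least 1.6-fold lower number from compound 2 to compound 4 (0.22 log units; that floor lies within the scatter). Compound 4 is expected to give about 60000 nM, within a range of 15000 nM to 200000 nM, with a real chance that it too returns only a limit.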

Compound 4, half-maximal inhibitory concentration: 44300 nM
Estimate against measurement, compound 4: 1.4-fold (0.13 log units) above; measured number inside the range.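

In this assay, putting 4-fluorophenyl in place of 1H-benzimidazol-2-yl on the saturated chain carbon bound to a sulfur gives an at least 2.2-fold lower number from compound 2 to compound 4 (0.35 log units; beyond the scatter). This is the first pair shown that differs in only one place, so it gives the first direct sign that the group carried on this sulfur changes the read-out, although the new number is still weak. The true size of the step remains unknown because compound 2 has only a limit, which makes the step a floor: the limit of > 100000 nM in this assay, at which 2 of the 4 values shown sit.

Going by these compounds, it remains open whether the fluorine contributes to this step, which a plain benzyl group on the same sulfur would help to show. A short chain such as ethyl, or a chain ending in an amine, would show whether a ring is needed there at all.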